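Ring-nitrogen substituent swap in a pyrazoline-type series

The compounds below may be only part of what the source reports. "The series", "measured", "known", "first", "only" and "open" are said of these compounds alone.

Among the compounds with values here, compound 2 `CN1CCN(c2ccc(C3=NN(C(=O)/C=C/c4ccccc4)C(c4ccc(N(C)C)cc4)C3)cc2)CC1` stands highest of the two numbers known in a functional assay on NCI-H1975 cells (Homo sapiens) for inhibition, read by sulforhodamine B assay, tested at 10 uM (on this read-out higher numbers stand for more inhibition at the one concentration tested (going by the name of the read-out) and lower numbers for less inhibition), at 81%; compound 1 `CN1CCN(c2ccc(C3=NNC(c4ccc(N(C)C)cc4)C3)cc2)CC1` gives 2.4%. Within the data shown here, the single measured step, a number 78.6 percentage points higher from compound 1 to compound 2 (beyond the scatter), shows that the group on that ring nitrogen decides the read-out. Compound 3 `CN1CCN(c2ccc(C3=NN(S(C)(=O)=O)C(c4ccc(N(C)C)cc4)C3)cc2)CC1` carries methylsulfonyl in place of (2-phenylethenyl)carbonyl on an amine nitrogen in a ring. Among the measured compounds shown here, no step with methylsulfonyl at this position is known, so the only guide is that compound 1, bare at this nitrogen, sits low. A fall from compound 2 is expected, a number 41 percentage points lower from compound 2 to compound 3 (beyond the scatter), but not all the way back. Compound 3 is estimated at 40%, between 5% and 75%.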

Compound 3, a percentage reported as inhibition, at one concentration (the size of the read-out at that concentration, not a potency): -1.3%
Beside the measured number, compound 3's estimate is 41.3 percentage points above it; the whole stated range lies above it.
By their numbers in this assay, from the lowest: compounds 3 and 1 (each within the scatter of the next); then compound 2.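

Putting a group on the amine nitrogen in the ring is not enough on its own: the change to methylsulfonyl gives a number 82.3 percentage points lower from compound 2 to compound 3 (beyond the scatter), and measured against the bare nitrogen it gives a number 3.7 percentage points lower from compound 1 to compound 3 (within the scatter). Among these compounds, the high number therefore goes with (2-phenylethenyl)carbonyl, not with substitution at this nitrogen as such. Nothing available explains the gap between these two groups.

Still open, as far as these compounds go, is whether a plain acetyl or benzoyl group at this nitrogen would keep any of the inhibition seen with compound 2. Also open, from the compounds shown here alone, is whether a phenylsulfonyl group would read like methylsulfonyl.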